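The source may report more compounds than this note shows. Statements on the series, on what has been measured and on what is new or still open speak of the compounds shown alone.

Working notes on the shared core of compound 1 `CCC1=C(O)c2c(oc(-c3cccc(C(F)(F)F)c3)cc2=O)C(CC)(CC)C1=O`. In a functional assay on KB cells (Homo sapiens) for antiproliferative activity, read by sulforhodamine B assay, with a stated time of 3 days (on this read-out lower numbers stand for an effect already at smaller amounts and higher numbers for an effect only at larger amounts of compound), compound 1 gives 35.7 uM. Compound 2 `CCC1=C(O)c2c(oc(-c3cccc(F)c3)cc2=O)C(CC)(CC)C1=O` stands at the limit of > 56.2 uM in this assay, at which 1 of the 2 values shown sits, reported in this assay as > 56.2 uM, a limit rather than a number. For the measured compounds named here, the only measured step, an at least 1.5-fold higher number from compound 1 to compound 2 (0.19 log units; that floor lies within the scatter), is therefore a floor. Compound 3 `CCC1=C(O)c2c(oc(-c3cccc(C)c3C)cc2=O)C(CC)(CC)C1=O` carries 2,3-dimethylphenyl in place of 3-fluorophenyl on an aromatic carbon. Going by the values given here, that step is the sole comparison available, and with compound 2 at a limit no direction beyond the scatter can be read from it. Compound 3 is expected at 50 uM, with a range from 15 uM to 150 uM. The step this estimate implies, an at least 1.1-fold lower number from compound 2 to compound 3 (0.05 log units; that floor lies within the scatter), is expected to stay within the scatter.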

Compound 3, concentration for half-maximal effect: 3.1 uM
Compound 3: the middle estimate sits 16-fold (1.21 log units) above what was measured, and the stated range ends above it.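

The aromatic group on this carbon next to the ring oxygen clearly moves the read-out in this assay. For the compounds shown here, the first step beyond the scatter is an at least 18-fold lower number from compound 2 to compound 3 (1.25 log units; beyond the scatter) and it comes with 2,3-dimethylphenyl in place of 3-fluorophenyl. The size of this step is only a floor, as compound 2 stands at a limit: the limit of > 56.2 uM in this assay, at which 1 of the 3 values shown sits.

Going by these compounds, the swap removes fluoro and adds two methyl groups at once, so the share of each change stays open. Also open, on these data alone, is how an amine or a carboxylic acid on this aromatic ring would read in this assay on the shared core.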